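A Fluoropiperidine in Place of a Methylcyclohexyl Amide

The source may hold more compounds than are shown below. What is called first, only, known or untested is meant among the compounds shown, and "the series" means these compounds.

Of the compounds shown here, three built on one shared core have been tested in an assay on HEK293 cells for positive allosteric modulation of metabotropic glutamate receptor 5 (Homo sapiens), read by FLIPR, with a stated time of 1 h; a higher number here means that more compound is needed for the effect, a lower number that less compound is needed. Compound 1 `CN1CCc2nc(C#Cc3ccccc3)sc2C1` gives 34 nM. Compound 2 `CC1CCC(C(=O)N2CCc3nc(C#Cc4ccccc4)sc3C2)CC1` gives 190 nM, the highest of the two numbers reported; compound 1 sits well below it, a gap beyond the usual scatter. Compound 3 `O=S(=O)(N1CCCCC1)N1CCc2nc(C#Cc3ccccc3)sc2C1` is known only through the limit of > 10000 nM in this assay, at which 1 of the 3 values shown sits: its reading of > 10000 nM is a limit of the assay and not a number.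

Compound 4 `O=C(N1CCC(F)CC1)N1CCc2nc(C#Cc3ccccc3)sc2C1` has not yet been measured. It differs from compound 2 in one place: 4-fluoropiperidin-1-yl in place of 4-methylcyclohexyl on a carbonyl carbon. Among the measured compounds shown here, no pair of measured compounds repeats this change, so its size can only be guessed. The carbonyl carbon keeps its amide-type nitrogen neighbour, but the carbon-only ring gives way to a ring holding a nitrogen and a fluorine. On these data, the step of a 3.7-fold higher number from compound 2 to compound 4 (0.57 log units; beyond the scatter) is expected to move toward a higher number, clearly beyond the scatter, yet to stop short of the limit reached by compound 3. Compound 4 is therefore estimated at 700 nM, with a likely range from 150 nM to 3500 nM.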

Compound 4, half-maximal effective concentration: 74 nM
For compound 4 the middle estimate is 9.5-fold (0.98 log units) above the measured one, and the stated range ends above it.
By their numbers in this assay, from the lowest: compound 1; then compound 4; then compound 2. At a limit, above all of these: compound 3.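

This position on the carbonyl carbon can take a different ring without a loss: in this assay the change to 4-fluoropiperidin-1-yl from 4-methylcyclohexyl gives a 2.6-fold lower number from compound 2 to compound 4 (0.41 log units; beyond the scatter) and so moves the compound toward needing less for the effect. The step is modest, yet it shows that a carbon-only ring is not required here, and that a ring holding a nitrogen and a fluorine serves at least as well on this amide-type carbonyl. The two groups match in heavy atoms, in hydrogen-bond donors and acceptors and in net charge, so those counts do not separate them, and nothing measured here gives a reason for the step.

The ring nitrogen and the fluorine entered together, so their shares in the step remain unresolved, and a plain piperidin-1-yl or a 4-fluorocyclohexyl group on the same carbonyl carbon would pull them apart. Also open, from the compounds shown here alone, is whether a morpholine or a 4,4-difluoropiperidine at this place would continue the move toward lower numbers or reverse it.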